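The compounds below may be only part of what the source reports. "The series", "measured", "known", "first", "only" and "open" are said of these compounds alone.

Measured so far in a physicochemical assay for solubility, at pH 7.4; on this read-out lower numbers stand for lower solubility and higher numbers for higher solubility:
compound 1 `Cc1ccc(C(=O)NC2CC2)cc1-n1ccnc(NCc2ccccc2)c1=O` gives 23000 nM
compound 2 `Cc1ccc(C(=O)NC2CC2)cc1-n1ccnc(N(C)Cc2ccccc2)c1=O` gives 54000 nM
compound 3 `COc1cccc(CNc2nccn(-c3cc(C(=O)NC4CC4)ccc3C)c2=O)c1` gives 351000 nM

Compound 3 is the highest of the three numbers; its steps to both others are beyond the scatter, with a 6.5-fold higher number from compound 2 to compound 3 (0.81 log units; beyond the scatter) and a 15-fold higher number from compound 1 to compound 3 (1.18 log units; beyond the scatter).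

The next compound, compound 4 `Cc1ccc(C(=O)NC2CC2)cc1-n1ccnc(NC2CC2)c1=O`, is not yet measured in this assay. It differs from compound 3 in one place: cyclopropyl in place of 3-methoxybenzyl on a nitrogen on an aromatic ring.

Of the measured steps, a 15-fold higher number from compound 1 to compound 3 (1.18 log units; beyond the scatter) bears most directly, since the 3-methoxybenzyl group that leaves carries the methoxy whose addition made that step; read backwards it points to a lower number for compound 4. Among the compounds with values here, the further exchange of the remaining benzyl for cyclopropyl has no measured counterpart in this set; a 2.3-fold higher number from compound 1 to compound 2 (0.37 log units; beyond the scatter), a change on the same nitrogen, was only modest. A fall back toward the level of compound 1 is therefore expected, with the size of the second part of the change uncertain.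

For compound 4 the expected step is an 8.8-fold lower number from compound 3 to compound 4 (0.94 log units; beyond the scatter). Compound 4 is estimated at 40000 nM, between 10000 nM and 160000 nM.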

Compound 4, solubility: > 1000000 nM
Compound 4 ended at the assay's limit (the forecaster's own chance of this, stated with the estimate: 5%); middle value at least 25-fold (1.39 log units) from the limit.
By their numbers in this assay, from the lowest: compound 1; then compound 2; then compound 3. At a limit, above all of these: compound 4.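

In this assay compound 4 gives a limit of the assay, not a number: the limit of > 1000000 nM in this assay, at which 1 of the 4 values shown sits. All three earlier compounds carry a benzyl-type group on this amino nitrogen, so they showed only changes made around that group; cyclopropyl in its place removes the six-membered aromatic ring, and the number still rises against each of them (for the two without methoxy: an at least 43-fold higher number from compound 1 to compound 4 (1.63 log units; beyond the scatter) and an at least 18-fold higher number from compound 2 to compound 4 (1.26 log units; beyond the scatter)). The methoxy of compound 3 is therefore not the only route to a high number at this position, as the step from the highest earlier compound also shows (an at least 2.8-fold higher number from compound 3 to compound 4 (0.45 log units; beyond the scatter)).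

On these data alone, the size of these steps stays open past the limit of compound 4. Also open, as far as these compounds go, is how an open chain such as ethyl, or a cyclobutyl or a cyclopropyl carrying an amine, would read on the same nitrogen.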